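The source may hold more compounds than are shown below. What is called first, only, known or untested is meant among the compounds shown, and "the series" means these compounds.

Measured in a functional assay on KYSE-510 cells (Homo sapiens) for antiproliferative activity, read by crystal violet staining, with a stated time of 96 h; a lower number here means a stronger inhibitor of growth, a higher number a weaker inhibitor of growth:

Compound 1, `COc1cccc(S(=O)(=O)NC2=NCCN2C(=S)SN2CCn3c2nsc3=S)c1`, gives >= 20000 nM, which is a limit of the assay and not a number.
Compound 2, `COc1ccc(S(=O)(=O)NC2=NCCN2C(=S)SN2CCn3c2nsc3=S)cc1`, gives >= 20000 nM, again a limit of the assay.
Compound 3, `O=S(=O)(NC1=NCCN1C(=S)SN1CCn2c1nsc2=S)c1ccc(Cl)c(Cl)c1Cl`, gives >= 20000 nM, also a limit of the assay.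

Compound 3 therefore stands where every measured compound stands: at the limit of >= 20000 nM in this assay, at which 3 of the 3 values shown sit. None of the three exchanges among these compounds can be read as a step in growth inhibition, since each is a move from one limit to another. The change a step that the two limits leave unreadable from compound 1 to compound 2 gives no readable size, and the same holds for a step that the two limits leave unreadable from compound 1 to compound 3 and for a step that the two limits leave unreadable from compound 2 to compound 3.

Compound 4, `O=S(=O)(NC1=NCCN1C(=S)SN1CCn2c1nsc2=S)c1cccc2ccccc12`, is not yet measured. It differs from compound 3 in one place: naphthalen-1-yl in place of 2,3,4-trichlorophenyl on a sulfonyl sulfur. Every measured step that bears on this position is unreadable, so there is no comparison showing that a change of the group on the sulfonyl sulfur moves the read-out of this assay in either direction. The expectation is accordingly that compound 4 also comes out at the limit, which means an expected step of a number no higher from compound 3 to compound 4 (the limit leaves the size open) in this assay. The estimated value for compound 4 is 20000 nM, with a range from 6000 nM to 60000 nM.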

Compound 4, concentration for 50% growth inhibition: >= 20000 nM
Compound 4: a limit, no number; the forecaster's own chance of this, stated with the estimate: 80%; the middle value lies on the limit itself.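

In this assay compound 4 gives >= 20000 nM, which is a limit of the assay and not a number. Its steps from compound 1, compound 2 and compound 3 therefore cannot be read, as each runs from one limit to another: the limit of >= 20000 nM in this assay, at which 4 of the 4 values shown sit.

The compounds shown leave open whether any group on the sulfonyl sulfur can bring the shared core to a readable value.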